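Phenyl for Methyl on a Potent Acylguanidine Scaffold

A few compounds are considered here, and "the series" means these few. Any claim that something is new, unique, unknown or untested is made for them only; others in the source may bear on it.

Three compounds have been measured so far:

Compound 1, `CS(=O)(=O)c1cc(C(=O)N=C(N)N)c(Cl)cc1Cl`, 140 nM
Compound 2, `Cc1c(C(=O)N=C(N)N)ccc(Cl)c1S(C)(=O)=O`, 1300 nM
Compound 3, `Cc1cc(C)c(S(C)(=O)=O)cc1C(=O)N=C(N)N`, 11 nM

In a functional assay for inhibition of sodium/hydrogen exchanger (Oryctolagus cuniculus) (a higher number here means a weaker inhibitor, a lower number a stronger inhibitor), compound 3 gives the lowest number of the three, and its separation from both others lies beyond the scatter: compound 1 gives 140 nM and compound 2 gives 1300 nM, so compound 3 is the strongest inhibitor in this set. The unmeasured compound 4, `Cc1cc(-c2ccccc2)c(S(C)(=O)=O)cc1C(=O)N=C(N)N`, is related to compound 3 by a single change, (phenyl in place of methyl on an aromatic carbon). Within the data shown here, no measured pair in the set reproduces this kind of exchange, so there is no step on which to anchor the expectation. What the set shows is that the numbers move widely with changes to the substituents on the shared core, and that compound 3 already sits at the low end. The author expects the phenyl to cost some potency, with a 3.6-fold higher number from compound 3 to compound 4 (0.56 log units; beyond the scatter) as the estimated step in this assay. Compound 4 is therefore estimated at 40 nM, within a range from 10 nM to 200 nM.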

Compound 4, half-maximal inhibitory concentration: 19 nM
For compound 4 the middle estimate is 2.1-fold (0.32 log units) above the measured one, and the stated range covers the measured number.
By their numbers in this assay, from the lowest: compounds 3 and 4 (each within the scatter of the next); then compound 1; then compound 2.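

In this assay, phenyl in place of methyl on the aromatic carbon ortho to the methylsulfonyl group gives a 1.7-fold higher number from compound 3 to compound 4 (0.24 log units; within the scatter), so within the scatter this exchange leaves the number unchanged. Among these compounds, the earlier compounds offered no step at all, and this pair is the first to show that, on this core, this position accepts a group of 6 heavy atoms with a six-membered aromatic ring in place of a single carbon without a change that can be told from the scatter.

Going by these compounds, whether an amine, a carboxylic acid or a longer alkyl chain on the same carbon would also leave the number unchanged remains open, and this reading rests on a single pair. Nothing measured here bears on why the two numbers stay so close.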